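The source may report more compounds than this note shows. Statements on the series, on what has been measured and on what is new or still open speak of the compounds shown alone.

Measured compounds:
compound 1 `Cc1c(Nc2nc(N)c3c(C#N)c(N4CCC[C@H]4C)n(C)c3n2)cnn1CC(C)(C)O`, 35 nM
compound 2 `Cn1c(N2CCCC2)c(C#N)c2c(N)ncnc21`, 1910 nM
compound 3 `C[C@@H]1CCCN1c1c(C#N)c2c(N)nc(N)nc2n1C`, 217 nM

In an assay on isolated protein for inhibition of Leucine-rich repeat serine/threonine-protein kinase 2 variant G2019S (Homo sapiens), read by TR-FRET and LanthaScreen, with stated times of 50 min and 30 min, in the presence of a further agent that is not named here (a lower number here means a stronger inhibitor, a higher number a weaker inhibitor), compound 2 gives 1910 nM, the highest of the three numbers. The nearest is compound 3 with 217 nM, the gap being beyond the scatter, and the furthest is compound 1 with 35 nM, also beyond the scatter. Compound 4 `Cn1c(N)c(C#N)c2c(N)ncnc21` has not yet been measured in this assay. Its difference from compound 2 is amino in place of pyrrolidin-1-yl on an aromatic carbon. Among the measured compounds shown here, no directly comparable step between two measured compounds is available, so the direction is uncertain. Compound 4 is expected to give a somewhat higher number than compound 2, with an estimated step of a 2.6-fold higher number from compound 2 to compound 4 (0.42 log units; beyond the scatter). Compound 4 is estimated at 5000 nM, within 1500 nM to 16000 nM.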

Compound 4, half-maximal inhibitory concentration: 8560 nM
Compound 4: middle estimate off by 1.7-fold (0.23 log units), on the low side; the measured number falls inside the stated range.
By their numbers in this assay, from the lowest: compound 1; then compound 3; then compound 2; then compound 4.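

In this assay, among the compounds shown here, the change from pyrrolidin-1-yl to amino on this aromatic carbon gives a 4.5-fold higher number from compound 2 to compound 4 (0.65 log units; beyond the scatter) and is the first single-place comparison in the set. It shows that the number at this position responds to the group it carries, and that the ring-bearing compound 2 is the stronger of the pair. No measurement shown explains this step. As far as these compounds go, whether dimethylamino or piperidin-1-yl would give a number nearer that of compound 2 or compound 4 remains open. So does whether the step would persist on the core of compound 1.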